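Three Limits and a Fluoro Replacement

The compounds below may be only part of what the source reports. "The series", "measured", "known", "first", "only" and "open" are said of these compounds alone.

Compound 1, `C=CC(=O)Oc1cc(C(F)(F)F)cc(C(F)(F)F)c1`: in an ADME assay for pharmacokinetics, read by LC-MS, in phosphate buffer, with a stated time of 72 h, at pH 7.4, tested at 250 uM (on this read-out lower numbers stand for a shorter-lived compound and higher numbers for a longer-lived compound), compound 1 gives < 0.017 h, which is a limit of the assay and not a number.
Compound 2, `C=CS(=O)(=O)c1cc(C(F)(F)F)cc(C(F)(F)F)c1`: in this assay compound 2 gives < 0.017 h, again a limit of the assay.
Compound 3, `O=C(CBr)c1cc(C(F)(F)F)cc(C(F)(F)F)c1`: in this assay compound 3 gives < 0.017 h, also a limit of the assay.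

Compound 3 therefore stands exactly where its two companions stand, at the limit of < 0.017 h in this assay, at which 3 of the 3 values shown sit. The three measured steps exchange one group for another on the shared core: a step that the two limits leave unreadable from compound 1 to compound 2, a step that the two limits leave unreadable from compound 1 to compound 3 and a step that the two limits leave unreadable from compound 2 to compound 3. None of them gives a readable size, so none puts a number on how much any of these groups matters.

Compound 4, `Fc1cc(C(F)(F)F)cc(C(F)(F)F)c1`, differs from compound 3 in one place: fluoro in place of (bromomethyl)carbonyl on an aromatic carbon. Within the data shown here, no measured step removes one of the three groups outright, so this change has no direct precedent among the measured pairs. Compound 4 carries none of the groups that sit at the limit of < 0.017 h in this assay, at which 3 of the 3 values shown sit, and its half-life in this assay is expected to be longer, with the step of an at least 2800-fold higher number from compound 3 to compound 4 (3.45 log units; beyond the scatter) estimated as upward. The estimate for compound 4 is 48 h, in a range from 5 h to 200 h, held loosely given that only limits are available.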

Compound 4, half-life: > 50 h
Compound 4 was reported as a limit (the forecaster's own chance of this, stated with the estimate: 50%); middle value at least 1.0-fold (0.01 log units) from the limit.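

Swapping each of the three groups for fluoro gives the first steps at this position on the shared core with a readable size in this assay, and all are large: an at least 2900-fold higher number from compound 3 to compound 4 (3.46 log units; beyond the scatter) on the loss of (bromomethyl)carbonyl, an at least 2900-fold higher number from compound 2 to compound 4 (3.46 log units; beyond the scatter) on the loss of vinylsulfonyl and an at least 2900-fold higher number from compound 1 to compound 4 (3.46 log units; beyond the scatter) on the loss of (vinylcarbonyl)oxy. Compound 4 gives > 50 h here, which is a limit of the assay and not a number, so its true half-life remains unread. The shared core can therefore last a long time in this buffer when it carries fluoro at this position, and the short half-lives go with the three groups that fluoro replaces: the limit of > 50 h in this assay, at which 1 of the 4 values shown sits.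

On these data alone, the steps among compound 1, compound 2 and compound 3 still cannot be read, so the order of those three groups stays unknown: the limit of < 0.017 h in this assay, at which 3 of the 4 values shown sit. Also open, as far as these compounds go, is whether an amine, a nitrile or a longer chain at this position would keep the half-life of compound 4 or land somewhere in the wide gap left by the two limits.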